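Swapping one group on a shared core at the limit

This account rests on a few compounds, and the source may have more. Where it says the series, first, only, none or still open, it means among the compounds named here.

In a functional assay on HeLa cells (Homo sapiens) for cytotoxicity, read by neutral red uptake, with a stated time of 3 days (a higher number here means a weaker inhibitor, a lower number a stronger inhibitor), compound 1 (`CCCCc1c(F)c(N)c2c(=O)cc(-c3ccc(N)c(F)c3)oc2c1F`) gives > 100000 nM as a limit. Compound 2 (`C[S+]([O-])c1c(F)c(N)c2c(=O)cc(-c3ccc(N)c(F)c3)oc2c1F`) likewise gives > 100000 nM as a limit, so it has no exact number. Compound 3 (`CN(C)c1c(F)c(N)c2c(=O)cc(-c3ccc(N)c(F)c3)oc2c1F`) differs from it by a group of 3 heavy atoms (2 carbon, 1 nitrogen; no ring) in place of a group of 3 heavy atoms (1 carbon, 1 oxygen, 1 sulfur; no ring), on an aromatic carbon on the shared core. Going by the values given here, the only evidence is the limit of > 100000 nM in this assay, at which 2 of the 2 values shown sit, and the one measured step that the two limits leave unreadable from compound 1 to compound 2 has no readable size. No step beyond the scatter and no direction can therefore be argued, and the expected step of a number no higher from compound 2 to compound 3 (the limit leaves the size open) is correspondingly small. For compound 3 the estimate is 100000 nM with an expected range of 40000 nM to 250000 nM in this assay and a reading at the limit is likely.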

Compound 3, half-maximal inhibitory concentration: > 100000 nM
Compound 3 ended at the assay's limit; the forecaster's own chance of this, stated with the estimate: 80%; the middle value sits exactly at the limit.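

Compound 1, compound 2 and compound 3 all sit at the same limit, so no step among them can be read: the limit of > 100000 nM in this assay, at which 3 of the 3 values shown sit.

The compounds shown leave open whether the group at this place on the shared core matters at all in this assay.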